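The compounds below may be only part of what the source reports. "The series", "measured", "known", "first", "only" and "open" are said of these compounds alone.

Three compounds share one core and differ only at a stereocentre at a saturated ring carbon. Compound 1 `CCOc1ccc(N/N=C2\CCC(C)n3c2ncc(C(=O)O)c3=O)cc1` is drawn without a configuration at that centre; in a functional assay on the whole organism for inhibition, with Rattus norvegicus as the target (on this read-out lower numbers stand for an effect already at smaller amounts and higher numbers for an effect only at larger amounts of compound), compound 1 gives 1.6 umol/kg, the second highest of the three numbers. Compound 2 `CCOc1ccc(N/N=C2\CC[C@@H](C)n3c2ncc(C(=O)O)c3=O)cc1` has that centre drawn as R, and in this assay compound 2 gives 0.2 umol/kg, so that the step is an 8.0-fold lower number from compound 1 to compound 2 (0.90 log units; beyond the scatter). Compound 3 `CCOc1ccc(N/N=C2\CC[C@H](C)n3c2ncc(C(=O)O)c3=O)cc1` has the centre drawn as S, and in this assay compound 3 gives 100 umol/kg; the step is a 63-fold higher number from compound 1 to compound 3 (1.80 log units; beyond the scatter), and between the two defined forms it is a 500-fold higher number from compound 2 to compound 3 (2.70 log units; beyond the scatter). What sets these pairs apart is only the configuration as drawn the fact that one of compounds 1 and 2 is drawn with a defined configuration and the other without, at the place where they differ the fact that one of compounds 1 and 3 is drawn with a defined configuration and the other without, at the place where they differ (the fact that compounds 2 and 3 differ only in the configuration as drawn).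

Compound 4 `CC1CC/C(=N\Nc2ccc(-c3ccccc3)cc2)c2ncc(C(=O)O)c(=O)n21` keeps the undefined centre of compound 1 and changes a different place: phenyl in place of ethoxy on an aromatic carbon. For the measured compounds named here, none of the measured steps touches this position, so they give no guide to its size or direction; the expectation is therefore a step near the scatter, with a wide range. Compound 4 is expected to give about 3 umol/kg, between 0.5 umol/kg and 20 umol/kg. That expectation amounts to an estimated 1.9-fold higher number from compound 1 to compound 4 (0.27 log units; within the scatter).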

Compound 4, dose for 50% inhibition: 1.1 umol/kg
Estimate against measurement, compound 4: 2.7-fold (0.44 log units) above, within the range that was stated.
By their numbers in this assay, from the lowest: compound 2; then compounds 4 and 1 (each within the scatter of the next); then compound 3.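

In this assay, phenyl in place of ethoxy on the aromatic carbon gives a 1.5-fold lower number from compound 1 to compound 4 (0.16 log units; within the scatter) and so leaves the read-out within the usual scatter. For the compounds shown here, this is the first reading at this position, as the earlier compounds varied only the stereocentre, and it shows that a larger group with an aromatic ring of carbon only and no hydrogen-bond acceptor can stand here in place of ethoxy without a change beyond the scatter. Nothing at hand speaks to why these two groups give such close numbers.

Still open, from the compounds shown here alone, is whether a very different group at this place, such as an amine, a carboxylic acid or a longer chain like butoxy, would be tolerated as well. Also open, going by these compounds, is how phenyl behaves when the stereocentre is defined as R or S, since compound 4 carries that centre undefined.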